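The compounds below may be only part of what the source reports. "The series", "measured", "known", "first", "only" and "open" are said of these compounds alone.

Measured in a functional assay on the whole organism with Rattus norvegicus as the target; on this read-out higher numbers stand for an effect only at larger amounts of compound and lower numbers for an effect already at smaller amounts:
compound 1, `CCOCCOC(=O)C(=O)Nc1nc(-c2cc(OCc3ccccc3)no2)cs1` — the value of compound 1 is a limit, > 100 mg/kg.
compound 2, `CCOCCOC(=O)C(=O)Nc1nc(-c2cc(C)no2)cs1` — compound 2 gives 1.3 mg/kg.
compound 3, `CCOCCOC(=O)C(=O)Nc1nc(-c2cc(COC)no2)cs1` — compound 3 gives 0.7 mg/kg.

Compound 3 holds the lower of the two numbers shown, with compound 2 within the scatter of it; the remaining value is a limit. Compound 4, `CCOCCOC(=O)C(=O)Nc1nc(-c2cc(-c3c(F)cccc3Cl)no2)cs1`, differs from compound 3 thus: 2-chloro-6-fluorophenyl in place of methoxymethyl on an aromatic carbon. Among the measured compounds shown here, the steps that bear on this run the opposite way, from a group carrying a six-membered aromatic ring to a small one: an at least 76-fold lower number from compound 1 to compound 2 (1.88 log units; beyond the scatter) and an at least 140-fold lower number from compound 1 to compound 3 (2.15 log units; beyond the scatter), both large, and compound 1 sits at the limit of > 100 mg/kg in this assay, at which 1 of the 3 values shown sits. Putting a group with a six-membered aromatic ring back onto that aromatic carbon is therefore expected to raise the number strongly, a 57-fold higher number from compound 3 to compound 4 (1.76 log units; beyond the scatter), and a limit is possible. Compound 4 is estimated at 40 mg/kg, within 5 mg/kg to 300 mg/kg.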

Compound 4, dose for half-maximal effect: > 30 mg/kg
Compound 4 was reported as a limit; the forecaster's own chance of this, stated with the estimate: 40%; the middle value does not contradict the limit.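

At the aromatic carbon next to the ring nitrogen, a six-membered aromatic ring bound directly also goes with a large loss, so the loss is not confined to the benzyloxy of compound 1: an at least 42-fold higher number from compound 3 to compound 4 (1.63 log units; beyond the scatter) and an at least 23-fold higher number from compound 2 to compound 4 (1.36 log units; beyond the scatter). Compound 4 stands at a limit, not a number: the limit of > 30 mg/kg in this assay, at which 1 of the 4 values shown sits. The step from compound 1 to compound 4 cannot be read.

Open, on these data alone, is how an unsubstituted phenyl, a primary amine or a longer ether chain would behave at this carbon. The compounds shown do not separate the ring itself from the chlorine and fluorine on it.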